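A few compounds are considered here, and "the series" means these few. Any claim that something is new, unique, unknown or untested is made for them only; others in the source may bear on it.

In a functional assay on A549 cells (Homo sapiens) for inhibition, read by MTT assay, with a stated time of 72 h (a lower number here means a stronger inhibitor, a higher number a weaker inhibitor), three compounds built on a shared core have been measured, and they differ only in the aromatic group on one ring carbon. Compound 1 `Cc1ccc(-c2cc(C(=O)N3CCC4(CC3)CC(=O)c3nn(C(C)(C)C)cc3O4)c3ccccc3n2)cc1`, carrying 4-methylphenyl, gives 5300 nM. Compound 2 `CC(C)(C)n1cc2c(n1)C(=O)CC1(CCN(C(=O)c3cc(-c4ccc(Br)cc4)nc4ccccc34)CC1)O2`, carrying 4-bromophenyl, gives 9300 nM. Compound 3 `COc1ccc(-c2cc(C(=O)N3CCC4(CC3)CC(=O)c3nn(C(C)(C)C)cc3O4)c3ccccc3n2)cc1OC`, carrying 3,4-dimethoxyphenyl, gives 2030 nM, the lowest number of the three and so the strongest inhibitor among them.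

Bromo in place of methyl gives a 1.8-fold higher number from compound 1 to compound 2 (0.24 log units; within the scatter). The 3,4-dimethoxyphenyl group gives larger, though still modest, steps: a 2.6-fold lower number from compound 1 to compound 3 (0.42 log units; beyond the scatter) and a 4.6-fold lower number from compound 2 to compound 3 (0.66 log units; beyond the scatter).

Compound 4 `CC(C)(C)n1cc2c(n1)C(=O)CC1(CCN(C(=O)c3cc(N4CCNCC4)nc4ccccc34)CC1)O2` has piperazin-1-yl in place of 3,4-dimethoxyphenyl on an aromatic carbon, next to the ring nitrogen (piperazin-1-yl in place of 3,4-dimethoxyphenyl on an aromatic carbon). This is a bigger change than any measured so far, since every measured step swaps one substituted phenyl group for another. None of them shows what a non-aromatic ring does at this carbon, so they offer only a rough guide. Compound 3 already sits at the low end, and the largest step at this carbon is a 4.6-fold lower number from compound 2 to compound 3 (0.66 log units; beyond the scatter). A modest move towards a higher number in this assay therefore seems the likeliest outcome, with wide uncertainty. The expected step is a 2.5-fold higher number from compound 3 to compound 4 (0.39 log units; beyond the scatter). For compound 4, the estimated value is 5000 nM, with an expected range from 1500 nM to 20000 nM.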

Compound 4, half-maximal inhibitory concentration: > 10000 nM
Compound 4 was reported as a limit; the forecaster's own chance of this, stated with the estimate: 15%; middle value at least 2.0-fold (0.30 log units) away from the limit.
By their numbers in this assay, from the lowest: compound 3; then compounds 1 and 2 (each within the scatter of the next). At a limit, above all of these: compound 4.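

Within the data shown here, until now, this aromatic carbon next to the ring nitrogen had carried only substituted phenyl groups, so compound 4 gives the first look at a non-aromatic ring there, piperazin-1-yl. In this assay, putting this ring in place of 3,4-dimethoxyphenyl gives an at least 4.9-fold higher number from compound 3 to compound 4 (0.69 log units; beyond the scatter), so the change clearly costs activity, and the lead that compound 3 holds among the phenyl compounds does not survive it. The comparisons with the other two phenyl compounds say much less, since the number for compound 4 is a limit and the floors of an at least 1.0-fold higher number from compound 2 to compound 4 (0.03 log units; that floor lies within the scatter) and an at least 1.8-fold higher number from compound 1 to compound 4 (0.27 log units; that floor lies within the scatter) lie within the scatter, so neither step can be read as a real difference.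

The compounds shown leave open whether this loss belongs to non-aromatic rings in general or to piperazin-1-yl alone. A morpholine ring, a piperidine ring or an open-chain amine on the same carbon would help to separate those two readings, while a pyridine ring would show how an aromatic ring containing nitrogen fares there.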